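The source may hold more compounds than are shown below. What is called first, only, known or untested is meant among the compounds shown, and "the series" means these compounds.

Measured compounds:
compound 1, `Cc1cc(C#N)cc(C)c1Oc1cc(Nc2ccc(C#N)cc2)c(N)cc1CO`, 122000 nM
compound 2, `Cc1cc(C#N)cc(C)c1Oc1cc(Nc2ccc(C#N)cc2)c(N)cc1CNC1CC1`, 12100 nM
compound 3, `Cc1cc(C#N)cc(C)c1Oc1cc(Nc2ccc(C#N)cc2)c(N)cc1CNCCCO`, 15100 nM

In an ADME assay on MT2 cells (Homo sapiens) for cytotoxicity (a lower number here means that less compound is tolerated, a higher number that more compound is tolerated), compound 3 stands second highest of the three numbers; its nearest neighbour is compound 2, at a 1.2-fold higher number from compound 2 to compound 3 (0.10 log units; within the scatter), and its furthest is compound 1, at an 8.1-fold lower number from compound 1 to compound 3 (0.91 log units; beyond the scatter). The step to the unmeasured compound 4, `Cc1cc(C#N)cc(C)c1Oc1cc(Nc2ccc(C#N)cc2)c(N)cc1CN1CCN(C)CC1`, is 4-methylpiperazin-1-yl in place of (3-hydroxypropyl)amino on a saturated chain carbon bound to an aromatic carbon.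

Within the data shown here, two measured steps bear on this change. Both replacements of hydroxy by an amine on that saturated chain carbon lowered the number: a 10-fold lower number from compound 1 to compound 2 (1.00 log units; beyond the scatter) and an 8.1-fold lower number from compound 1 to compound 3 (0.91 log units; beyond the scatter). Between the two amines themselves the step was a 1.2-fold higher number from compound 2 to compound 3 (0.10 log units; within the scatter), within the scatter. Compound 4 keeps an amine on the same carbon, so the two amine-bearing compounds are the closer guide, and no step beyond the scatter is expected in this assay, with at most a small drift toward a lower number because the amines of compound 2 and compound 3 both gave a 10-fold lower number from compound 1 to compound 2 (1.00 log units; beyond the scatter) and an 8.1-fold lower number from compound 1 to compound 3 (0.91 log units; beyond the scatter) relative to the hydroxy compound. The expected step is a 1.5-fold lower number from compound 3 to compound 4 (0.18 log units; within the scatter). Compound 4 is therefore estimated at 10000 nM, in a range from 3500 nM to 30000 nM.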

Compound 4, half-maximal cytotoxic concentration: 96900 nM
Compound 4: the middle estimate sits 9.7-fold (0.99 log units) below what was measured, outside the stated range (above it).
By their numbers in this assay, from the lowest: compounds 2 and 3 (each within the scatter of the next); then compounds 4 and 1 (each within the scatter of the next).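

In this assay, placing an amine on the saturated chain carbon bound to an aromatic carbon does not by itself bring the low numbers seen so far. With 4-methylpiperazin-1-yl there the result is a 6.4-fold higher number from compound 3 to compound 4 (0.81 log units; beyond the scatter) and an 8.0-fold higher number from compound 2 to compound 4 (0.90 log units; beyond the scatter), so the identity of the amine matters at this position, and the two earlier amines do not speak for all amines. Set against hydroxy, the same group gives a 1.3-fold lower number from compound 1 to compound 4 (0.10 log units; within the scatter) and so stays within the scatter of the hydroxy compound, unlike cyclopropylamino and (3-hydroxypropyl)amino.

The compounds shown leave open whether this follows the ring itself or its methyl group, which piperazin-1-yl, morpholin-4-yl or an open-chain dimethylamino group could separate. Nothing measured here explains the difference between these amines.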